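Methylating the Amide Nitrogen of a Cyclopropylmethoxy Agonist

The compounds below may be only part of what the source reports. "The series", "measured", "known", "first", "only" and "open" are said of these compounds alone.

For the measured compounds named here, compound 1 `N#Cc1c(N)nc(SCC(N)=O)c(C#N)c1-c1ccc(OCC2CC2)cc1` gives the lower of the two numbers so far recorded in a functional assay on CHO cells for agonist activity at adenosine receptor A2b (Homo sapiens), read by AlphaScreen and cAMP accumulation (on this read-out higher numbers stand for an effect only at larger amounts of compound and lower numbers for an effect already at smaller amounts), where compound 1 gives 31 nM. Going by the values given here, its only measured neighbour is compound 2 `CC(=O)Nc1ccc(-c2c(C#N)c(N)nc(SCC(N)=O)c2C#N)cc1`, which carries an acetamido in place of the cyclopropylmethoxy on an aromatic carbon; in this assay compound 2 gives 164 nM. Among the compounds with values here, the single measured step, a 5.3-fold higher number from compound 1 to compound 2 (0.72 log units; beyond the scatter), therefore concerns the aryl substituent alone.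

Compound 3 `CNC(=O)CSc1nc(N)c(C#N)c(-c2ccc(OCC3CC3)cc2)c1C#N` differs from compound 1 by methyl in place of hydrogen on an amide-type nitrogen. Within the data shown here, the one measured step touches a different part of the shared core and offers no direct guide to a change on the amide-type nitrogen. Compound 3 is thus expected to move only slightly, a step of a 1.5-fold higher number from compound 1 to compound 3 (0.16 log units; within the scatter) that may well remain within the usual scatter. Compound 3 is estimated at 45 nM in this assay, with a likely range from 15 nM to 150 nM.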

Compound 3, half-maximal effective concentration: 94 nM
The estimate for compound 3 lay 2.1-fold (0.32 log units) below the measured number; the range from low to high includes it.
By their numbers in this assay, from the lowest: compound 1; then compounds 3 and 2 (each within the scatter of the next).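

The amide nitrogen of the side chain proves to be a position that responds: in this assay, methyl in place of hydrogen there gives a 3.0-fold higher number from compound 1 to compound 3 (0.48 log units; beyond the scatter) and so adds a second measured change to the one on the aryl substituent. A single added carbon on this nitrogen, far from the aryl substituent in the structure's naming, is enough to raise the number beyond the scatter, so the carbamoyl end of the side chain cannot be treated as free to alter. No measurement at hand accounts for this shift.

The compounds shown leave open whether an ethyl or a cyclopropyl on the same nitrogen would raise the number further, and how a carboxylic acid in place of the carbamoyl would read. As far as these compounds go, whether the same methyl would act alike alongside the acetamido of compound 2 also remains open.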